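A few compounds are considered here, and "the series" means these few. Any claim that something is new, unique, unknown or untested is made for them only; others in the source may bear on it.

Measured so far in an ADME assay on BHK15 cells (Mesocricetus auratus) for inhibition, read by XTT assay, with a stated time of 36 h; on this read-out lower numbers stand for stronger inhibition of growth and higher numbers for weaker inhibition of growth:

Compound 1 `NC(=O)c1sc(-c2ccc(Cl)cc2)nc1C(Br)Br` gives 99700 nM.
Compound 2 `CCN(CC)C(=O)c1sc(-c2ccc(Cl)cc2)nc1C(Br)Br` gives 63500 nM.
Compound 3 `C#CCNC(=O)c1sc(-c2ccc(Cl)cc2)nc1C(Br)Br` gives 23900 nM.

Compound 1 shows the highest number of the three. Its nearest neighbour is compound 2, reached by a 1.6-fold lower number from compound 1 to compound 2 (0.20 log units; within the scatter); its furthest is compound 3, reached by a 4.2-fold lower number from compound 1 to compound 3 (0.62 log units; beyond the scatter). The step followed here leads to compound 4 `CCOC(=O)c1sc(-c2ccc(Cl)cc2)nc1C(Br)Br`, which has not yet been measured. The change is ethoxy in place of amino on a carbonyl carbon.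

Going by the values given here, two measured steps bear on this. Exchanging amino for diethylamino on the carbonyl carbon gave a 1.6-fold lower number from compound 1 to compound 2 (0.20 log units; within the scatter), and putting propargyl in place of hydrogen on the amide-type nitrogen gave a 4.2-fold lower number from compound 1 to compound 3 (0.62 log units; beyond the scatter). Both changes at the carbonyl carbon lowered the number, one only mildly and one modestly. Ethoxy is another change at the same place, so a small lowering in this assay is expected, and it may well stay within the scatter. Compound 4 is therefore estimated at 50000 nM, with a range from 20000 nM to 120000 nM. This estimate corresponds to an expected step of a 2.0-fold lower number from compound 1 to compound 4 (0.30 log units; within the scatter).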

Compound 4, concentration for 50% growth inhibition: 94600 nM
Compound 4: middle estimate off by 1.9-fold (0.28 log units), on the low side; the measured number falls inside the stated range.
By their numbers in this assay, from the lowest: compound 3; then compounds 2, 4 and 1 (each within the scatter of the next).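

In this assay, the step of a 1.1-fold lower number from compound 1 to compound 4 (0.02 log units; within the scatter) shows that ethoxy can replace amino on this carbonyl carbon, and so remove the hydrogen-bond donor there, with no change beyond the scatter. Ethoxy also sits level with diethylamino, with a 1.5-fold higher number from compound 2 to compound 4 (0.17 log units; within the scatter) as the printed step, while the move away from propargylamino gives a 4.0-fold higher number from compound 3 to compound 4 (0.60 log units; beyond the scatter) and so leaves compound 3 as the only one of the four that stands apart. Nothing measured here accounts for this difference.

As far as these compounds go, it remains open whether the lower number of compound 3 belongs to the propargyl group itself or would also appear with a plain ethylamino group on the same carbonyl carbon. From the compounds shown here alone, a free carboxylic acid at this place, or a longer chain such as butoxy, also remains untested by these compounds.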